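A Second Chloro on the Fused Ring of Compound 2

A few compounds are considered here, and "the series" means these few. Any claim that something is new, unique, unknown or untested is made for them only; others in the source may bear on it.

Two compounds have been measured so far in a functional assay on the whole organism for inhibition, with Rattus norvegicus as the target, at a dose of 25 mg/kg by the oral route; a lower number here means less inhibition, a higher number more inhibition at the dose given (going by the name of the read-out):
Compound 1 `O=C(O)Cc1nn(Cc2nc3ccccc3s2)c(=O)c2ccccc12` gives 67%.
Compound 2 `O=C(O)Cc1nn(Cc2nc3ccc(Cl)cc3s2)c(=O)c2ccccc12` gives 61%.

Among the compounds with values here, compound 2 holds the lower of the two numbers, but its only neighbour is compound 1, and the step of a number 6 percentage points lower from compound 1 to compound 2 (within the scatter) lies within the scatter, so the two compounds cannot be told apart on these numbers.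

Compound 3 `O=C(O)Cc1nn(Cc2nc3cc(Cl)c(Cl)cc3s2)c(=O)c2ccccc12` differs from compound 2 in one place: chloro in place of hydrogen on an aromatic carbon. Within the data shown here, one measured step bears on this change, a number 6 percentage points lower from compound 1 to compound 2 (within the scatter), where chloro likewise replaced hydrogen on an aromatic carbon of the same fused system; it stayed within the scatter. Among the measured compounds shown here, with only that one step to go by, no movement beyond the scatter is expected from adding the further chloro, and the estimate simply carries the number of compound 2 forward with a somewhat widened range. The expected step is a number 3 percentage points lower from compound 2 to compound 3 (within the scatter). Compound 3 is therefore estimated at 58%, with a range from 40% to 74%.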

Compound 3, a percentage reported as inhibition, in the whole organism at one dose (the size of the read-out at that dose, not a potency): 34%
Compound 3: middle estimate off by 24 percentage points, on the high side, outside the stated range (below it).
By their numbers in this assay, from the lowest: compound 3; then compounds 2 and 1 (each within the scatter of the next).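

In this assay the second chloro gives a number 27 percentage points lower from compound 2 to compound 3 (beyond the scatter) while the first chloro gave a number 6 percentage points lower from compound 1 to compound 2 (within the scatter) on the same ring, so the same exchange of hydrogen for chloro does not have to give a step of the same size each time. Within the data shown here, the new chloro sits on an aromatic carbon ortho to a chloro group, meta to a fused ring and para to a fused ring, and this is the first single change to move the number beyond the scatter. Nothing at hand accounts for the drop.

The compounds shown do not separate the place from the pair: compound 3 is the only one with two chloro groups, so a lone chloro at this new place could behave like the chloro of compound 2 or could bring the drop by itself. On these data alone, whether a different group at this place, such as fluoro, methyl or methoxy, would lower the number as well also stays open.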